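The source may report more compounds than this note shows. Statements on the series, on what has been measured and on what is new or still open speak of the compounds shown alone.

Compound 1 `CCCN(CCC)S(=O)(=O)c1ccc(S(=O)(=O)N2CCC[C@@H](C(=O)OCC)C2)cc1` is the reference point of this account. In a functional assay on MIA PaCa-2 cells (Homo sapiens) for inhibition, read by MTT assay, with a stated time of 3 days (a higher number here means a weaker inhibitor, a lower number a stronger inhibitor), compound 1 gives > 10000 nM, which is a limit of the assay rather than a number. Compound 2 `CCN(CC)S(=O)(=O)c1ccc(S(=O)(=O)N2CCC[C@@H](C(=O)N3CCN(c4nc(C(F)(F)F)no4)CC3)C2)cc1` carries a different amide on the shared core. In this assay compound 2 gives > 10000 nM, again only a limit. Compound 3 `CCN(CC)S(=O)(=O)c1ccc(S(=O)(=O)N2CCC[C@@H](C(=O)NC)C2)cc1` is the simple methylamide. In this assay compound 3 gives > 10000 nM, also a limit. Within the data shown here, every measured value thus sits at the limit of > 10000 nM in this assay, at which 3 of the 3 values shown sit, so no step between measured compounds can be sized, and compound 1 stands at that limit alongside the others rather than at any ranked position.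

Compound 4 `CCOC(=O)[C@@H]1CCCN(S(=O)(=O)c2ccc(S(=O)(=O)N(C)C)cc2)C1` has not yet been measured. It differs from compound 1 by dimethylamino in place of dipropylamino on a sulfonyl sulfur. Among the measured compounds shown here, with every measured compound at the limit there is no measured step to lean on. The step in this assay is expected to be a step that the limit leaves unreadable from compound 1 to compound 4, nothing beyond the scatter. Compound 4 is expected to give 15000 nM in this assay, within a range from 5000 nM to 50000 nM, most likely reported as a limit once more.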

Compound 4, half-maximal inhibitory concentration: > 10000 nM
Compound 4: a limit, no number; the forecaster's own chance of this, stated with the estimate: 80%; the middle value does not contradict the limit.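

In this assay compound 4 gives > 10000 nM as a limit of the assay, so the step from compound 1 to compound 4 cannot be read: (the limit of > 10000 nM in this assay, at which 4 of the 4 values shown sit). The compounds shown leave open whether any change on the shared core gives a readable value in this assay at all.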